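The compounds below may be only part of what the source reports. "The series", "measured", "known", "first", "only" and "open" are said of these compounds alone.

Measured in a functional assay on the whole organism with Rattus norvegicus as the target, at a dose of 100 mg/kg; a lower number here means less inhibition, a higher number more inhibition at the dose given (going by the name of the read-out):
compound 1 `CC/N=C(\S)NCCCCCCn1nc(-c2ccccc2)ccc1=O` gives -5.6%
compound 2 `O=c1ccc(-c2ccccc2)nn1CCCCNC(=S)NC1CCCCC1` gives 18.1%
compound 3 `C=CCNC(=S)NCCCCn1nc(-c2ccccc2)ccc1=O` gives 27.1%

Compound 3 holds the highest number of the three; compound 2 lies within the scatter of it, and compound 1 lies clearly below, a number 32.7 percentage points higher from compound 1 to compound 3 (beyond the scatter). Compound 4 `CN(C)/C(=N/CCCn1nc(-c2ccccc2)ccc1=O)NC#N` differs from compound 3 by a group of 8 heavy atoms (4 carbon, 4 nitrogen; no ring) in place of a group of 8 heavy atoms (5 carbon, 2 nitrogen, 1 sulfur; no ring), on a saturated chain carbon, three bonds along the chain from an aromatic nitrogen. Among the measured compounds shown here, the only measured step that alters the same part of the molecule is a number 32.7 percentage points higher from compound 1 to compound 3 (beyond the scatter), large but leading toward compound 3; the step of a number 9 percentage points higher from compound 2 to compound 3 (within the scatter) changes only the end of that group and stays within the scatter. Neither step tests the change now made, so the data give no direction. A downward step a number 13.1 percentage points lower from compound 3 to compound 4 (beyond the scatter) is expected, toward the middle of the measured span. Compound 4 is estimated at 14%, within -10% to 38%.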

Compound 4, a percentage reported as inhibition, in the whole organism at one dose (the size of the read-out at that dose, not a potency): 72.2%
Beside the measured number, compound 4's estimate is 58.2 percentage points below it, and the stated range ends below it.
By their numbers in this assay, from the lowest: compound 1; then compounds 2 and 3 (each within the scatter of the next); then compound 4.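

In this assay, exchanging the sulfur-bearing group at this position for the group of 4 carbon and 4 nitrogen atoms gives a number 45.1 percentage points higher from compound 3 to compound 4 (beyond the scatter). The earlier compounds shown here all carry sulfur in this group, so only now is it seen that the position can hold a sulfur-free group while the number rises. No measurement here bears on the reason for the rise.

As far as these compounds go, the step replaces the whole group at once, so it remains open which part of it carries the rise. Also open, from the compounds shown here alone, is how a urea or a longer chain would read at this position.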